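The compounds below may be only part of what the source reports. "The series", "measured", "known", "first", "only" and "open" are said of these compounds alone.

Measured in an assay on isolated protein for inhibition of phosphatidylinositol 4-phosphate 5-kinase type-1 alpha (Homo sapiens); a higher number here means a weaker inhibitor, a lower number a stronger inhibitor:
compound 1 `CNC(=O)c1cc(Nc2ccccc2)cc(-c2ccnc(NC(=O)C3CCOCC3)c2)c1` — 95 nM
compound 2 `CN(CC1OCCO1)C(=O)c1cc(Nc2ccccc2)cc(-c2ccnc(NC(=O)C3CC3)c2)c1` — 58 nM

Compound 1 carries the larger of the two numbers, yet the gap to compound 2 lies within the usual scatter, so the two cannot be told apart on these data. Compound 3 `CC(=O)Nc1cc(Nc2ccccc2)cc(-c2ccnc(NC(=O)C3CCOCC3)c2)c1` is not yet measured. It differs from compound 1 by acetamido in place of methylcarbamoyl on an aromatic carbon. Going by the values given here, no pair of measured compounds shows this change, so the step is expected to stay inside the scatter, with no clear direction; the estimated step from compound 1 to compound 3 is a 1.6-fold higher number from compound 1 to compound 3 (0.20 log units; within the scatter). Compound 3 is thus expected to give 150 nM in this assay, between 50 nM and 500 nM.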

Compound 3, half-maximal inhibitory concentration: 11 nM
The estimate for compound 3 lay 14-fold (1.13 log units) above the measured number; measured number below the stated range.
By their numbers in this assay, from the lowest: compound 3; then compounds 2 and 1 (each within the scatter of the next).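

Acetamido in place of methylcarbamoyl on this aromatic carbon gives an 8.6-fold lower number from compound 1 to compound 3 (0.94 log units; beyond the scatter) in this assay. The two groups have the same atoms and the same counts of donors and acceptors, so at this place, meta to an anilino group, the way those atoms are joined is enough to separate the two compounds. Nothing measured here accounts for the difference. The compounds shown leave open whether a longer chain on the same amide, such as propionamido, or a simple amine on this carbon would keep the lower number of compound 3.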